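Cyclopentyl for methyl on the aryl ether oxygen

The source may hold more compounds than are shown below. What is called first, only, known or untested is meant among the compounds shown, and "the series" means these compounds.

Compound 1 `COc1ccc(/C=C2\NC(=O)N(CCCN3CCN(c4ccccc4OC)CC3)C2=O)cc1OC` in an assay on CHO cells for displacement of a labelled ligand from 5-hydroxytryptamine receptor 7 (Homo sapiens), read by scintillation counting, with a stated time of 60 min (on this read-out lower numbers stand for stronger inhibition and higher numbers for weaker inhibition), gives 42 nM. Compound 2 `COc1ccc(/C=C2\NC(=O)N(CCCN3CCN(c4cccc(Cl)c4Cl)CC3)C2=O)cc1OC` gives 22 nM and compound 3 `COc1ccc(/C=C2\NC(=O)N(CCCN3CCN(c4ncccn4)CC3)C2=O)cc1OC` gives 74 nM. Compound 1 sits in the middle of the three numbers; both of its neighbouring steps, a 1.9-fold lower number from compound 1 to compound 2 (0.28 log units; within the scatter) and a 1.8-fold higher number from compound 1 to compound 3 (0.25 log units; within the scatter), remain within the scatter, so no ordering of compound 1 against compound 2 or compound 3 can be read from them. Only a 3.4-fold higher number from compound 2 to compound 3 (0.53 log units; beyond the scatter) reaches beyond the scatter. All three measured steps exchange the group on an amine nitrogen in a ring and leave the remainder of the shared core untouched.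

Compound 4 `COc1ccc(/C=C2\NC(=O)N(CCCN3CCN(c4ccccc4OC)CC3)C2=O)cc1OC1CCCC1` differs from compound 1 by cyclopentyl in place of methyl on an oxygen on an aromatic ring. Going by the values given here, none of the measured steps touches that oxygen, so no step bears on this change directly, and the numbers give no ground to expect a shift beyond the scatter. The expected step is therefore no change at the digits printed from compound 1 to compound 4 (within the scatter), with a broad range to reflect the missing precedent. For compound 4 the estimate is 42 nM, expected to fall from 12 nM to 150 nM.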

Compound 4, inhibition constant: 6 nM
Estimate against measurement, compound 4: 7.0-fold (0.85 log units) above; measured number below the stated range.
By their numbers in this assay, from the lowest: compound 4; then compounds 2, 1 and 3 (each within the scatter of the next, the first and the last beyond it).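

Methoxy to cyclopentyloxy gives a 7.0-fold lower number from compound 1 to compound 4 (0.85 log units; beyond the scatter) in this assay, so the group on this oxygen on an aromatic ring can move the number, and a five-membered non-aromatic ring of carbon only is accepted there. Of the steps out of compound 1, this is the only one that lies beyond the scatter; the changes on the amine nitrogen in a ring stay within it. Nothing available gives a reason for the step.

On these data alone, whether an open chain such as butyl or a smaller ring such as cyclopropyl on the same oxygen gives a similar number remains open. Also open, as far as these compounds go, is whether cyclopentyl in place of methyl gives a comparable step with the 2,3-dichlorophenyl of compound 2 or the pyrimidin-2-yl of compound 3.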